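The source may report more compounds than this note shows. Statements on the series, on what has been measured and on what is new or still open speak of the compounds shown alone.

Series notes. Compound 1 `CCC1=C(O)c2c(oc(-c3ccc(OC)cc3)cc2=O)C(CC)(CC)C1=O` is the reference point; in a functional assay on KB cells (Homo sapiens) for antiproliferative activity, read by sulforhodamine B assay, with a stated time of 3 days (on this read-out higher numbers stand for an effect only at larger amounts of compound and lower numbers for an effect already at smaller amounts), compound 1 gives 17.7 uM, the lowest number among the three measured compounds. Compound 2 `CCC1=C(O)c2c(oc(-c3ccc(OC(F)(F)F)cc3)cc2=O)C(CC)(CC)C1=O` gives 36.5 uM and compound 3 `CCC1=C(O)c2c(oc(-c3ccccc3C(F)(F)F)cc2=O)C(CC)(CC)C1=O` gives 45.6 uM; both numbers lie beyond the scatter from that of compound 1. Among the compounds with values here, the one single-site step measured so far, a 2.1-fold higher number from compound 1 to compound 2 (0.31 log units; beyond the scatter), shows that exchanging the group on the pendant aromatic ring moves the number only modestly. Compound 4 `CCC1=C(O)c2c(oc(-c3ccc(C)c(F)c3)cc2=O)C(CC)(CC)C1=O` has not yet been measured. It differs from compound 1 by 3-fluoro-4-methylphenyl in place of 4-methoxyphenyl on an aromatic carbon. Within the data shown here, the step from compound 1 to compound 2 is the only measured step that changes this ring, and it bears on the new change only loosely, since neither a fluorine nor a methyl on that ring has been measured. Taking it as the nearest guide, a modest step toward a higher number is expected for compound 4, a 1.7-fold higher number from compound 1 to compound 4 (0.23 log units; within the scatter). For compound 4 the expected value in this assay is 30 uM, with a range from 12 uM to 75 uM.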

Compound 4, concentration for half-maximal effect: 28.1 uM
The estimate for compound 4 lay 1.1-fold (0.03 log units) above the measured number; low and high end bracket the measured number.
By their numbers in this assay, from the lowest: compounds 1, 4, 2 and 3 (each within the scatter of the next, the first and the last beyond it).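

In this assay, exchanging 4-methoxyphenyl for 3-fluoro-4-methylphenyl on the aromatic carbon next to the ring oxygen gives a 1.6-fold higher number from compound 1 to compound 4 (0.20 log units; within the scatter), so this position accepts a change of two substituents on the aryl group without a step beyond the scatter. The leaving group counts one hydrogen-bond acceptor and the entering group none, so for this pair the oxygen of the methoxy group is not needed to keep the number within the scatter of compound 1. No measurement at hand explains this result.

The separate contributions of the fluorine and the methyl remain open, as neither stands alone on this ring among the compounds shown. Also open, as far as these compounds go, is how an amine, a carboxylic acid or a longer alkyl chain on this aryl group would move the number.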